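Benzyl versus aryl on the ring nitrogen

The compounds below may be only part of what the source reports. "The series", "measured", "known", "first", "only" and "open" are said of these compounds alone.

Compound 1, `C/N=C1\S/C(=C\c2cc(C)n(Cc3ccccc3F)c2C)C(=O)N1C`, is the reference point of this pair. Among the measured compounds shown here, in a functional assay for agonist activity at sphingosine 1-phosphate receptor 5 (Homo sapiens) (a lower number here means that less compound is needed, a higher number that more compound is needed for the effect), compound 1 gives 51 nM, the lowest of the two numbers measured so far. For the measured compounds named here, compound 2, `COCC/N=C1\S/C(=C\c2cc(C)n(-c3ccc(F)cc3F)c2C)C(=O)N1C`, gives 2100 nM in this assay, a gap from compound 1 that lies beyond the scatter; compound 2 differs from compound 1 in more than one place, so no single step between them can be read.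

Compound 3, `C/N=C1\S/C(=C\c2cc(C)n(-c3ccc(F)cc3)c2C)C(=O)N1C`, has not been measured. It carries 4-fluorophenyl in place of 2-fluorobenzyl on an aromatic nitrogen, with the aryl group now attached directly to the ring nitrogen rather than through a methylene.

Nothing measured isolates this change. Going by the values given here, compound 2, the only other member with an aryl group directly on that nitrogen, gives 2100 nM, but its differing imine substituent prevents attribution. A loss of potency is expected, with the step from compound 1 to compound 3 estimated at a 5.9-fold higher number from compound 1 to compound 3 (0.77 log units; beyond the scatter) in this assay. Compound 3 is thus expected to give about 300 nM, within a range of 80 nM to 1500 nM.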

Compound 3, half-maximal effective concentration: 652 nM
Compound 3: middle estimate off by 2.2-fold (0.34 log units), on the low side; the range from low to high includes it.
By their numbers in this assay, from the lowest: compound 1; then compound 3; then compound 2.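

Among the compounds shown here, replacing 2-fluorobenzyl with 4-fluorophenyl on the aromatic nitrogen gives the first readable step, and in this assay the step is large (a 13-fold higher number from compound 1 to compound 3 (1.11 log units; beyond the scatter)). The position is therefore sensitive to this change with the rest of the core of compound 1 held constant, which the gap between compound 1 and compound 2 could not show. The steps linking compound 2 to compound 1 or compound 3 cannot be read, and nothing available explains the new step.

The step combines two changes, the loss of the benzyl carbon link and the different fluorine placement, so their separate contributions remain unresolved. The 4-fluorobenzyl and 2-fluorophenyl groups would separate them, while unsubstituted benzyl would show what the fluorine contributes.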